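A few compounds are considered here, and "the series" means these few. Any claim that something is new, unique, unknown or untested is made for them only; others in the source may bear on it.

Measured so far:
compound 1, `CC1(C)CC(NC(=S)Nc2ccc(C#N)cc2)c2cc(F)ccc2O1`, 11000 nM
compound 2, `CC1(C)CC(NC(=S)Nc2ccc([N+](=O)[O-])cc2)c2cc(F)ccc2O1`, 3000 nM
compound 3, `CC1(C)CC(NC(=S)Nc2cccc([N+](=O)[O-])c2)c2cc(Cl)ccc2O1`, 3000 nM

In a functional assay on U-373MG ATCC cells (Homo sapiens) for inhibition, read by MTT assay, with a stated time of 72 h (on this read-out lower numbers stand for stronger inhibition and higher numbers for weaker inhibition), compound 2 gives 3000 nM and compound 1 gives 11000 nM. The change from compound 2 to compound 1 is cyano in place of nitro on an aromatic carbon and produced a 3.7-fold higher number from compound 2 to compound 1 (0.56 log units; beyond the scatter). Compound 3 gives 3000 nM in this assay, level with compound 2 at the digits shown; the difference between the cores of compound 3 and compound 2 is not broken down here.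

Compound 4, `CC1(C)CC(NC(=S)Nc2cccc(C#N)c2)c2cc(Cl)ccc2O1`, is not yet measured in this assay. It differs from compound 3 by cyano in place of nitro on an aromatic carbon. The place is not the same as before: para to a large group in compound 1, meta to a large group in compound 4, so this is the same kind of change, not the same change.

For compound 4 a step of about a 3.3-fold higher number from compound 3 to compound 4 (0.52 log units; beyond the scatter) is expected, resting on a 3.7-fold higher number from compound 2 to compound 1 (0.56 log units; beyond the scatter); the differing place widens the range. Compound 4 is thus estimated at 10000 nM, between 4000 nM and 25000 nM.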

Compound 4, half-maximal inhibitory concentration: 7000 nM
Compound 4: middle estimate off by 1.4-fold (0.15 log units), on the high side; the measured number falls inside the stated range.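

In this assay, cyano in place of nitro again raises the number, with a 2.3-fold higher number from compound 3 to compound 4 (0.37 log units; beyond the scatter), and the step carries over from one core to the other in direction and, within the scatter, in size: the same change on two cores in this assay, a 3.7-fold higher number (0.56 log units; beyond the scatter) from compound 2 to compound 1 and a 2.3-fold higher number (0.37 log units; beyond the scatter) from compound 3 to compound 4, 1.6-fold (0.20 log units) apart, within the scatter of two such steps.
Going by these compounds alone, this rests on only two pairs, which differ in the core and also in the place of the change (para to a large group in compound 1, meta to a large group in compound 4), so the contributions of core and place cannot be separated.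
It gives no cause for the step and no assurance for cores beyond these two.

Only nitro and cyano appear as substituents on this aromatic ring in the compounds shown. Going by these compounds, how an amine or a carboxylic acid at that carbon would compare remains open.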